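The source may hold more compounds than are shown below. What is called first, only, known or untested is meant among the compounds shown, and "the series" means these compounds.

Measured in a functional assay on OVCAR-5 cells (Homo sapiens) for cytotoxicity, read by sulforhodamine B assay, with a stated time of 48 h, tested at 0.001 uM; on this read-out higher numbers stand for a weaker effect at the one concentration tested and lower numbers for a stronger effect:
compound 1 `COc1cc(C)cc(-c2c(-c3ccnc(-c4ccc(N(C)C)cc4)c3)cnn2CC#N)c1` gives 90%
compound 2 `COc1cc(C)cc(-c2nn(CC#N)cc2-c2ccnc(-c3ccc(N(C)C)cc3)c2)c1` gives 98%
compound 3 `COc1cc(C)cc(-c2nn(CC#N)cc2-c2ccc(-c3cccc(C(C)=O)c3)nc2)c1` gives 74%

Compound 2 carries the highest of the three numbers in this assay. Its nearest neighbour is compound 1, whose number lies within the scatter of that of compound 2, so the two cannot be told apart or ordered. Compound 3 stands furthest away, its number lying beyond the scatter below that of compound 2; no single-place difference between compound 2 and compound 3 is recorded, so only the two values themselves can be compared. For the measured compounds named here, no pair of measured compounds in this set differs in just one place, so no measured step is available to calibrate any change.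

Compound 4 `Cc1cc(O)cc(-c2nn(CC#N)cc2-c2ccnc(-c3ccc(N(C)C)cc3)c2)c1` is not yet measured. It differs from compound 2 in one place: hydrogen in place of methyl on an oxygen on an aromatic ring Cut one bond further out, the change reads methoxy to hydroxy, or 3-methoxy-5-methylphenyl to 3-hydroxy-5-methylphenyl.

Nothing in the measured set shows what this change does in this assay. Going by the values given here, with no measured step to lean on, the expected change from compound 2 to compound 4 is small, a number 3 percentage points lower from compound 2 to compound 4 (within the scatter), none beyond the scatter in either direction. Compound 4 is therefore estimated at 95% in this assay. For compound 4 the expected range runs from 82% to 104%.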

Compound 4, a percentage reported as activity, at one concentration (the size of the read-out at that concentration, not a potency): 96%
Estimate against measurement, compound 4: 1 percentage points below, within the range that was stated.
By their numbers in this assay, from the lowest: compound 3; then compounds 1, 4 and 2 (each within the scatter of the next).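

In this assay, for the compounds shown here, the change from methoxy to hydroxy supplies the first single-place step, which reads a number 2 percentage points lower from compound 2 to compound 4 (within the scatter) and gives a first calibration for this position, on an oxygen on an aromatic ring. Here the methyl on that oxygen can give way to hydrogen with no difference that can be told from the scatter, so in this pair the read-out does not depend on that methyl. The step comes from a single low concentration and describes the size of the read-out there, not potency, and nothing at hand accounts for the result.

Still open, going by these compounds, is whether a larger group on the same oxygen, such as ethyl or a longer chain, or an amine in place of the hydroxy, would move the number in this assay beyond the scatter. Also open, on these data alone, is whether the same change from methoxy to hydroxy would have a similar outcome on the core of compound 3, which gives 74% in this assay and has no single-place partner yet.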